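This account rests on a few compounds, and the source may have more. Where it says the series, first, only, none or still open, it means among the compounds named here.

Two compounds with a shared core of the kind seen in compound 1 `COc1cccc(C(=O)N2CCCCC2CCOc2ccc(Cl)c(Cl)c2)c1` have been measured in a functional assay on CHO cells for antagonist activity at Orexin/Hypocretin receptor type 1 (Homo sapiens), read by FLIPR; on this read-out lower numbers stand for stronger inhibition and higher numbers for weaker inhibition. Compound 1 gives 126 nM in this assay, and compound 2 `N#Cc1cccc(C(=O)N2CCCCC2CCOc2ccc(Cl)c(Cl)c2)c1` gives 398 nM. Among the measured compounds shown here, the only measured step is a 3.2-fold higher number from compound 1 to compound 2 (0.50 log units; beyond the scatter), so compound 2 stands with the highest of the two numbers in this assay, its nearest neighbour being compound 1.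

The next compound, compound 3 `O=C(c1ccc(Cl)c(Cl)c1)N1CCCCC1CCOc1ccc(Cl)c(Cl)c1`, differs from compound 2 in one place: 3,4-dichlorophenyl in place of 3-cyanophenyl on a carbonyl carbon. For the measured compounds named here, the one measured step bears on it only indirectly, in that it shows the same carbonyl-bound aryl ring tolerating an exchange of its substituent with a modest change in this assay, from compound 1 to compound 2. Going by the values given here, no measured step covers a dichlorophenyl ring at that position, so the direction for compound 3 is open. Compound 3 is therefore expected to land near its two neighbours in this assay, with the estimate 220 nM and a range from 60 nM to 800 nM. This estimate corresponds to an expected step of a 1.8-fold lower number from compound 2 to compound 3 (0.26 log units; within the scatter), not beyond the scatter with confidence.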

Compound 3, inhibition constant: 2510 nM
Beside the measured number, compound 3's estimate is 11-fold (1.06 log units) below it; measured number above the stated range.
By their numbers in this assay, from the lowest: compound 1; then compound 2; then compound 3.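

The position on the carbonyl carbon, whose other neighbour is the amide-type nitrogen in a ring, proves more sensitive in this assay than the exchange of methoxy for cyano had suggested: replacing 3-cyanophenyl with 3,4-dichlorophenyl gives a 6.3-fold higher number from compound 2 to compound 3 (0.80 log units; beyond the scatter), and replacing 3-methoxyphenyl with the same group gives a 20-fold higher number from compound 1 to compound 3 (1.30 log units; beyond the scatter). The second of these steps is large, whereas a 3.2-fold higher number from compound 1 to compound 2 (0.50 log units; beyond the scatter) is modest, so the choice of aryl substituents here can move the number considerably, and among these three compounds the group 3,4-dichlorophenyl is the least favourable, with compound 3 the weakest. Nothing available explains why the dichlorophenyl group gives the weaker inhibition.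

Among the compounds shown here, with only three compounds, it remains open whether the rise follows from the presence of the chlorines themselves or from the particular combination in 3,4-dichlorophenyl, and how an amine or a carboxylic acid on this aryl ring would read in this assay. Going by these compounds, it is also open whether the same order of these three aryl groups would hold if the rest of the shared core changed, for example with a longer chain in place of the present one.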